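Ring swap on compound 3: expected solubility of compound 4

The source may hold more compounds than are shown below. What is called first, only, known or untested is meant among the compounds shown, and "the series" means these compounds.

In a physicochemical assay for solubility, using the shake flask method, in phosphate buffer, measured as kinetic solubility, with a stated time of 20 h, at pH 6.5 (a lower number here means a less soluble compound, a higher number a more soluble compound), compound 1 `FC(F)(F)Oc1ccc(-c2nc3cnc(Nc4ccccn4)cc3[nH]2)cc1` gives < 5000 nM, a limit of the assay and not a number. For the measured compounds named here, compound 2 `FC(F)(F)c1ccc(Nc2cc3[nH]c(C4CCCC4)nc3cn2)nc1` gives 145000 nM and compound 3 `FC1(F)CCC(c2nc3cnc(Nc4ccc(C(F)(F)F)cn4)cc3[nH]2)C1` gives 120000 nM, so compound 3 stands level with the only other compound that has a number. Compound 4 `FC(F)(F)c1ccc(Nc2cc3[nH]c(C4CCOCC4)nc3cn2)nc1` carries oxan-4-yl in place of 3,3-difluorocyclopentyl on an aromatic carbon. Going by the values given here, the one measured step at this place, a 1.2-fold lower number from compound 2 to compound 3 (0.08 log units; within the scatter), stayed within the scatter, and no measured step brings in oxan-4-yl. The expected step in this assay is a 1.2-fold higher number from compound 3 to compound 4 (0.07 log units; within the scatter), which is none beyond the scatter. For compound 4 the estimate is 140000 nM, with an expected range of 70000 nM to 280000 nM.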

Compound 4, solubility: 155000 nM
Estimate against measurement, compound 4: 1.1-fold (0.04 log units) below; low and high end bracket the measured number.
By their numbers in this assay, from the lowest: compounds 3, 2 and 4 (each within the scatter of the next). At a limit, below all of these: compound 1.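

In this assay, swapping in oxan-4-yl on this aromatic carbon of the five-membered aromatic ring leaves the number within the scatter of both earlier compounds (a 1.3-fold higher number from compound 3 to compound 4 (0.11 log units; within the scatter)) and (a 1.1-fold higher number from compound 2 to compound 4 (0.03 log units; within the scatter)). Cyclopentyl, 3,3-difluorocyclopentyl and oxan-4-yl therefore stand level here, so a ring oxygen in place of the two fluorines brings no step beyond the scatter. Nothing measured here bears on why these three compounds stand level. Still open, from the compounds shown here alone, is whether an amine or a carboxylic acid at this position would move the number beyond the scatter. Going by these compounds, a longer chain in place of the ring is equally open.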